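A few compounds are considered here, and "the series" means these few. Any claim that something is new, unique, unknown or untested is made for them only; others in the source may bear on it.

In a toxicity assay on HT-29 cells (Homo sapiens) for cytotoxicity (on this read-out lower numbers stand for higher toxicity in this test and higher numbers for lower toxicity in this test), compound 1 `CN1C(=S)[C@@H](NC(=O)c2nc(Cc3ccccc3)n(C)n2)COc2ccccc21` gives > 100000 nM, which is a limit and not a number. Compound 2 `CC(C)n1nc(C(=O)N[C@H]2COc3ccccc3N(C)C2=S)nc1Cc1ccccc1` likewise gives only a limit, > 100000 nM. Compound 3 `CN1C(=S)[C@@H](NC(=O)c2nc(Cc3ccccc3)n(C3CCCC3)n2)COc2ccccc21` also stands at a limit, > 100000 nM, so its place on the scale is known only from that limit.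

The step followed here leads to compound 4 `CN1C(=S)[C@@H](NC(=O)c2nc(Cc3ccccc3)n(C3CCOCC3)n2)COc2ccccc21`, which carries oxan-4-yl in place of cyclopentyl on an aromatic nitrogen. The measured steps that bear on it are changes on the same aromatic nitrogen. Isopropyl in place of methyl gives a step that the two limits leave unreadable from compound 1 to compound 2, cyclopentyl in place of methyl gives a step that the two limits leave unreadable from compound 1 to compound 3, and cyclopentyl in place of isopropyl gives a step that the two limits leave unreadable from compound 2 to compound 3. None of these steps has a readable size, and none of them brings in a ring with a hetero atom. What they do show is the limit of > 100000 nM in this assay, at which 3 of the 3 values shown sit.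

The expectation therefore rests on that shared limit, and no shift in either direction is expected in this assay beyond the scatter. The expected step is a number no higher from compound 3 to compound 4 (the limit leaves the size open). The estimate for compound 4 is 100000 nM, with an expected range from 50000 nM to 200000 nM, and a report of only a limit is the likely outcome.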

Compound 4, half-maximal cytotoxic concentration: > 100000 nM
Compound 4 gave a limit, no number; the forecaster's own chance of this, stated with the estimate: 90%; the middle value lies on the limit itself.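

In this assay compound 4 gives > 100000 nM, which is a limit and not a number. No step from compound 1, compound 2 or compound 3 to compound 4 can be read, and all four compounds share one result: the limit of > 100000 nM in this assay, at which 4 of the 4 values shown sit.

The compounds shown leave open how the groups on the aromatic nitrogen compare, and where any of these compounds lies on the scale of this assay.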